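The compounds below may be only part of what the source reports. "The series", "measured", "known", "first", "only" and "open" are said of these compounds alone.

Measured so far in a functional assay on MV4-11 cells (Homo sapiens) for antiproliferative activity, with a stated time of 6 days, tested at 6.25 uM; on this read-out lower numbers stand for a weaker effect and higher numbers for a stronger effect at the one concentration tested:
- compound 1 `CNC(=O)N1CCCc2ccc(NC(=O)c3ccc(-c4cc[nH]n4)cc3)cc21`: 99.1%
- compound 2 `CNC(=O)N1CCCc2ccc(NC(=O)c3ccc(-c4ccn(C(C)=O)n4)cc3)cc21`: 91.4%
- compound 3 `CNC(=O)N1CCCc2ccc(NC(=O)c3ccc(-c4ccccn4)cc3)cc21`: 79.2%

Compound 3 gives the lowest of the three numbers in this assay. Its nearest neighbour is compound 2, and the gap between them is beyond the scatter: a number 12.2 percentage points lower from compound 2 to compound 3 (beyond the scatter). Compound 1 lies further away: a number 19.9 percentage points lower from compound 1 to compound 3 (beyond the scatter). Both of these steps put pyridin-2-yl in place of a pyrazole ring and both ran downward by a modest amount.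

Compound 4 `CNC(=O)N1CCCc2ccc(NC(=O)c3ccc(-c4cnn(S(C)(=O)=O)c4)cc3)cc21` has not yet been measured. It differs from compound 3 in a single place: 1-(methylsulfonyl)-1H-pyrazol-4-yl in place of pyridin-2-yl on an aromatic carbon. The two measured steps above are the ones that bear on this change, since they show what happens when a pyrazole is exchanged for pyridin-2-yl; compound 4 reverses that exchange. Among the measured compounds shown here, the pyrazole it brings in, 1-(methylsulfonyl)-1H-pyrazol-4-yl, is joined through a different ring atom and carries a methylsulfonyl group on its nitrogen, and no measured pair tests either feature, so the reversal cannot be assumed to be complete. A modest upward step in this assay is therefore expected, of about the size seen between compound 2 and compound 3.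

Compound 4 is expected to give 89% in this assay, between 75% and 98%, which means an estimated step of a number 9.8 percentage points higher from compound 3 to compound 4 (within the scatter).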

Compound 4, a percentage reported as inhibition, at one concentration (the size of the read-out at that concentration, not a potency): 40.2%
The estimate for compound 4 lay 48.8 percentage points above the measured number; the whole stated range lies above it.
By their numbers in this assay, from the lowest: compound 4; then compound 3; then compounds 2 and 1 (each within the scatter of the next).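

In this assay, among the compounds shown here, a pyrazole at this position does not guarantee a high number: putting 1-(methylsulfonyl)-1H-pyrazol-4-yl in place of pyridin-2-yl gives a number 39 percentage points lower from compound 3 to compound 4 (beyond the scatter) and reverses the direction of the earlier steps between pyrazoles and pyridin-2-yl. The same group also stands well under both earlier pyrazoles, with a number 51.2 percentage points lower from compound 2 to compound 4 (beyond the scatter) and a number 58.9 percentage points lower from compound 1 to compound 4 (beyond the scatter), so the kind of pyrazole and what it carries matter far more here than the presence of a pyrazole ring alone, and compound 4 goes against any simple rule that pyrazoles beat pyridin-2-yl. No measurement at hand accounts for this large fall.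

Compound 4 differs from the other pyrazoles both in the ring atom that joins the ring to the core and in the methylsulfonyl group on its nitrogen, and the compounds shown cannot separate these two changes. A plain 1H-pyrazol-4-yl group, with only hydrogen on the ring nitrogen, or a 1-methyl-1H-pyrazol-4-yl group would show whether the joining atom or the methylsulfonyl group is tied to the lower number.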